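A few compounds are considered here, and "the series" means these few. Any claim that something is new, unique, unknown or untested is made for them only; others in the source may bear on it.

In a functional assay on MKN-45 cells (Homo sapiens) for cytotoxicity, read by MTT assay, with a stated time of 48 h (on this read-out higher numbers stand for weaker inhibition and lower numbers for stronger inhibition), compound 2 `COc1cc(-c2nnc(SCC(=O)c3ccc(C)cc3)n2N2C(=O)c3ccccc3C2=O)cc(OC)c1OC` gives 9620 nM, the only plain number shown. Compound 1 `CCc1nnc(SCC(=O)c2ccc(C)cc2)n1N1C(=O)c2ccccc2C1=O` reaches only a limit of the assay, at > 200000 nM. Going by the values given here, the single measured step, an at least 20-fold lower number from compound 1 to compound 2 (1.31 log units; beyond the scatter), concerns a different place on the molecule. Compound 3 `COc1cc(-c2nnc(SCC(=O)c3ccc(Br)cc3)n2N2C(=O)c3ccccc3C2=O)cc(OC)c1OC` differs from compound 2 by bromo in place of methyl on an aromatic carbon. Among the compounds with values here, no measured step touches this place, so nothing argues for a change beyond the usual scatter in this assay. Compound 3 is therefore expected to give about 9600 nM, likely between 3000 nM and 30000 nM, an estimated 1.0-fold lower number from compound 2 to compound 3 (0.00 log units; within the scatter).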

Compound 3, half-maximal inhibitory concentration: 22300 nM
For compound 3 the middle estimate is 2.3-fold (0.37 log units) below the measured one; the measured number falls inside the stated range.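

Going by these compounds alone, replacing methyl with bromo gives the first measured step at this place, on the aromatic carbon para to a large group: a 2.3-fold higher number from compound 2 to compound 3 (0.37 log units; beyond the scatter). In this assay, this place is therefore not indifferent, as exchanging one heavy atom for another moves the number modestly towards weaker inhibition.

Going by these compounds, whether an amine or a carboxylic acid here would lower the number remains open, as does whether the same exchange would have a similar effect with ethyl in place of 3,4,5-trimethoxyphenyl. Nothing shown accounts for this step.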